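This account rests on a few compounds, and the source may have more. Where it says the series, first, only, none or still open, it means among the compounds named here.

Compound 1 `O=C(Nc1ccc(-n2ccc3c(NC(=O)c4ccccc4)ncnc32)cc1)Nc1ccc(Cl)c(C(F)(F)F)c1`: 6000 nM in an ADME assay on HS27 cells (Homo sapiens) for antiproliferative activity, read by MTT assay, with a stated time of 24 h; on this read-out higher numbers stand for weaker inhibition and lower numbers for stronger inhibition.
Compound 2 `Nc1ncnc2c1ccn2-c1ccc(NC(=O)Nc2ccc(Cl)c(C(F)(F)F)c2)cc1`: > 10000 nM in this assay.

Compound 2 gives only a limit in this assay, (the limit of > 10000 nM in this assay, at which 1 of the 2 values shown sits), so its value is not a number. Compound 3 `Nc1ncnc2c1ccn2-c1ccc(NC(=O)Nc2ccc(Cl)c(Cl)c2)cc1` differs from compound 2 by chloro in place of trifluoromethyl on an aromatic carbon. Within the data shown here, the one measured step, an at least 1.6-fold higher number from compound 1 to compound 2 (0.22 log units; that floor lies within the scatter), changed a different part of the structure and offers no guide to this swap, so no step tells the size or direction to expect beyond the scatter. For compound 3 the expected step is a step that the limit leaves unreadable from compound 2 to compound 3. Compound 3 is estimated at 12000 nM, with a range from 4000 nM to 40000 nM.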

Compound 3, half-maximal inhibitory concentration: 2900 nM
Beside the measured number, compound 3's estimate is 4.1-fold (0.62 log units) above it; the whole stated range lies above it.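

In this assay, chloro in place of trifluoromethyl on this aromatic carbon gives an at least 3.4-fold lower number from compound 2 to compound 3 (0.53 log units; beyond the scatter), and a lower number here stands for stronger inhibition. This is the first sign among the compounds shown that this position on the ring can move the read-out beyond the scatter. From the compounds shown here alone, the full size of the step stays unknown, since compound 2 gives only a limit: the limit of > 10000 nM in this assay, at which 1 of the 3 values shown sits.

Going by these compounds, whether a methyl, a nitrile or a fluorine at this position would move the number the same way remains open. So does whether this swap would act alike in compound 1, which carries the benzoyl group.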